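The compounds below may be only part of what the source reports. "The series", "measured", "known", "first", "only" and "open" are said of these compounds alone.

Of the compounds shown here, three sharing one core have been measured in a functional assay on the whole organism (strain Wistar albino) for inhibition, with Rattus norvegicus as the target, read by paw edema, with stated times of 30 min and 4 h, at a dose of 20 mg/kg by the oral route; a higher number here means more inhibition at the dose given (going by the name of the read-out), a lower number less inhibition. Compound 1 `Cc1cc(=O)oc2cc(OC(=O)CNc3ccccc3[N+](=O)[O-])ccc12` gives 15.2%, compound 2 `Cc1cc(=O)oc2cc(OC(=O)CNc3nc4ccccc4s3)ccc12` gives 40.6%, and compound 3 `Cc1cc(=O)oc2cc(OC(=O)CNc3ccccc3Cl)ccc12` gives 23.7%. Among these three, compound 3 stands second highest; its nearest neighbour is compound 1, and the two lie within the scatter of each other, while compound 2 lies beyond the scatter above it.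

The next compound, compound 4 `Cc1cc(=O)oc2cc(OC(=O)CNc3nccs3)ccc12`, differs from compound 3 in one place: 1,3-thiazol-2-yl in place of 2-chlorophenyl on an amine nitrogen.

Within the data shown here, only one measured step touches this series, a number 8.5 percentage points higher from compound 1 to compound 3 (within the scatter), and it concerns a swap on the aromatic ring rather than a swap of the whole ring, so it bears on the present change only loosely. More telling is what the values of compound 2 and compound 3 show: compound 2, whose amine nitrogen carries a fused ring that contains the same 1,3-thiazol-2-yl pattern, gives the highest number of the three. The expectation is therefore a step upward from compound 3 to compound 4 of about a number 8.3 percentage points higher from compound 3 to compound 4 (within the scatter), though a step this size could still fall within the scatter. Compound 4 is expected to give about 32% in this assay, within a range from 18% to 46%.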

Compound 4, a percentage reported as inhibition, in the whole organism at one dose (the size of the read-out at that dose, not a potency): 32.3%
Compound 4: middle estimate off by 0.3 percentage points, on the low side; measured number inside the range.
By their numbers in this assay, from the lowest: compounds 1, 3, 4 and 2 (each within the scatter of the next, the first and the last beyond it).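

In this assay, exchanging the whole ring on the amine nitrogen gives a number 8.6 percentage points higher from compound 3 to compound 4 (within the scatter), so 1,3-thiazol-2-yl can stand in place of 2-chlorophenyl at this position with no difference that outruns the scatter, even though the new ring is five-membered, holds two hetero atoms and carries no chlorine. Among these compounds, the earlier step changed only a group on the ring, so this is the first sign that the ring itself can be exchanged here, and since compound 4 at 32.3% and compound 2 at 40.6% also lie within the scatter of each other, compound 4 cannot be told apart from either compound 3 or compound 2 in this read-out. Nothing available explains the size of this step.

As far as these compounds go, whether a cyclohexyl ring, a pyridine ring or a plain phenyl ring without chlorine on the same amine nitrogen would read alike remains open. From the compounds shown here alone, each number also gives the size of the effect at a single dose, so how these compounds compare in potency stays open as well.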